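A few compounds are considered here, and "the series" means these few. Any claim that something is new, unique, unknown or untested is made for them only; others in the source may bear on it.

Measured compounds:
Compound 1 `COc1ccc(/C=C/[C@H]2CC=CC(=O)O2)cc1`: > 100000 nM
Compound 2 `COc1ccc(/C=C/[C@@H]2CC=CC(=O)O2)cc1`: > 100000 nM

In a functional assay on HBL-100 cells (Homo sapiens) for antiproliferative activity, read by luminescence and CellTiter-Glo, with a stated time of 48 h (a higher number here means a weaker inhibitor, a lower number a stronger inhibitor), compound 2 gives > 100000 nM, which is a limit and not a number. Compound 1 gives > 100000 nM, also a limit. Among the compounds with values here, the one measured step is a step that the two limits leave unreadable from compound 1 to compound 2. It concerns (the fact that compounds 1 and 2 differ only in the configuration as drawn), so it gives no size for a change on the aromatic ring. Compound 3 `O=C1C=CC[C@@H](/C=C/c2ccc(F)cc2)O1` carries fluoro in place of methoxy on an aromatic carbon, with fluoro in place of methoxy on an aromatic carbon. Within the data shown here, no measured step bears on this change, so no direction can be drawn from the data, and this assay may again return only a limit. The expected step is an at least 1.2-fold lower number from compound 2 to compound 3 (0.09 log units; that floor lies within the scatter). The estimate for compound 3 is 80000 nM, with an expected range from 20000 nM to 200000 nM.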

Compound 3, half-maximal inhibitory concentration: > 100000 nM
Compound 3 was reported as a limit; the forecaster's own chance of this, stated with the estimate: 55%; middle value at least 1.2-fold (0.09 log units) from the limit.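

In this assay compound 3 gives > 100000 nM, again a limit and not a number. Within the data shown here, compound 2 also stands at a limit, so no step between compound 2 and compound 3 can be read. The compounds shown leave open whether methoxy or fluoro on the aromatic ring makes any difference in this assay.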